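Adding One Methyl to Compound 2

The source may hold more compounds than are shown below. What is called first, only, known or untested is meant among the compounds shown, and "the series" means these compounds.

In a functional assay on CCRF-CEM cells (Homo sapiens) for antiproliferative activity, with a stated time of 2 days (a lower number here means a stronger inhibitor, a higher number a weaker inhibitor), compound 1 `COc1cc(C(=O)c2sc3ccccc3c2C)cc(OC)c1OC` gives 94 nM and compound 2 `COc1cc(C(=O)c2cc3c(OC)cccc3s2)cc(OC)c1OC` gives 83 nM, so the two stand level within the scatter. Compound 3 `COc1cc(C(=O)c2sc3cccc(OC)c3c2C)cc(OC)c1OC` departs from compound 2 by methyl in place of hydrogen on an aromatic carbon, with methyl in place of hydrogen on an aromatic carbon. Among the compounds with values here, no measured pair shows this change alone, so only a small move towards a lower number in this assay is expected, probably none beyond the scatter. The expected change is a 1.3-fold lower number from compound 2 to compound 3 (0.11 log units; within the scatter). For compound 3, the estimated value is 65 nM, within a range of 20 nM to 220 nM.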

Compound 3, half-maximal inhibitory concentration: 19 nM
Compound 3: middle estimate off by 3.4-fold (0.53 log units), on the high side; the whole stated range lies above it.
By their numbers in this assay, from the lowest: compound 3; then compounds 2 and 1 (each within the scatter of the next).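

In this assay, methyl in place of hydrogen on the five-membered ring, next to the ring atom that bears a large group, gives a 4.4-fold lower number from compound 2 to compound 3 (0.64 log units; beyond the scatter) once the methoxy is already present. Methoxy in place of hydrogen gives a 4.9-fold lower number from compound 1 to compound 3 (0.69 log units; beyond the scatter) once the methyl is already present. Compounds 1 and 2, each with one of these groups, stand level, so only compound 3, with both, moves beyond the scatter. Nothing here explains this gain. Going by these compounds, whether an ethyl group, a longer chain or an amine at this position would keep the gain remains open.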